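The compounds below may be only part of what the source reports. "The series", "measured", "known", "first", "only" and "open" are said of these compounds alone.

Going by the values given here, in a functional assay on COLO 205 cells (Homo sapiens) for inhibition (on this read-out lower numbers stand for stronger inhibition of growth and higher numbers for weaker inhibition of growth), compound 1 `COc1cccc(-c2nn(-c3ccccc3)cc2-c2ccnc(NCCNC(=O)Nc3cccc(C(F)(F)F)c3)c2)c1` gives 3340 nM and compound 2 `O=C(NCCCNc1cc(-c2cn(-c3ccccc3)nc2-c2cccc(O)c2)ccn1)c1ccccc1` gives 3670 nM; the two numbers lie within the scatter of each other, so compound 2 stands level with the only other measured compound. Compound 3 `O=C(NCCCNc1cc(-c2cn(-c3ccccc3)nc2-c2cccc(O)c2)ccn1)c1ccc(F)cc1` differs from compound 2 by fluoro in place of hydrogen on an aromatic carbon, which one bond further out reads as phenyl to 4-fluorophenyl on the benzamido group. Among the compounds with values here, no measured pair shows this change. For compound 3 the expected step is a 1.1-fold lower number from compound 2 to compound 3 (0.05 log units; within the scatter), nothing beyond the scatter in either direction. Compound 3 is estimated at 3300 nM, with a range from 1500 nM to 7500 nM.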

Compound 3, concentration for total growth inhibition: 3780 nM
Estimate against measurement, compound 3: 1.1-fold (0.06 log units) below; low and high end bracket the measured number.
By their numbers in this assay, from the lowest: compounds 1, 2 and 3 (each within the scatter of the next).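

Going by these compounds alone, the step on the benzamido group in this assay reads a 1.0-fold higher number from compound 2 to compound 3 (0.01 log units; within the scatter) and gives the first reading of a change on this ring: fluoro on an aromatic carbon, para to a large group, leaves the number level with that of the plain phenyl. No measurement on hand speaks to why this step is so small. On these data alone, whether a larger substituent at this position, such as a carboxylic acid or a dimethylamino group, would move the number remains open. So does the effect of a longer chain between the amide and the core.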